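This account rests on a few compounds, and the source may have more. Where it says the series, first, only, none or still open, it means among the compounds named here.

Measured compounds:
compound 1, `O=C(/C=C/c1ccc(F)cc1)O/C(=N/C1CCCCC1)NC1CCCCC1`, 82.5%
compound 2, `COC(=O)[C@H](COC(=O)/C=C/c1ccc(F)cc1)NC(=O)/C=C/c1ccc(F)cc1`, 21.1%
compound 3, `COC(=O)c1coc(/C=C/c2ccc(F)cc2)n1`, 102%

The three compounds were tested in an ADME assay on Vero cells (Chlorocebus sabaeus) for cytotoxicity, read by WST assay, tested at 50 ug/mL; a lower number here means a stronger effect, a higher number a weaker effect of the compound at the concentration tested. Compound 3 stands at the top of the three numbers with 102%. Its nearest neighbour is compound 1, whose reading of 82.5% lies lower, beyond the scatter of this assay. Furthest away is compound 2, whose reading of 21.1% lies far lower, again beyond the scatter. Among the measured compounds shown here, no pair among the three differs in a single place, so no step between measured compounds is drawn.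

The next compound, compound 4, is `COC(=O)c1coc(/C=C/c2ccc(OC)cc2)n1`. It differs from compound 3 by methoxy in place of fluoro on an aromatic carbon. For the measured compounds named here, nothing among the measured compounds shows what this exchange does in this assay, so the expectation rests on compound 3 alone, whose reading sits at the weak end of the scale. A small step at most is expected, and none beyond the scatter; the step expected is a number 6 percentage points lower from compound 3 to compound 4 (within the scatter). Compound 4 is therefore estimated to give 96%, with a range from 75% to 110%.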

Compound 4, a percentage reported as activity, at one concentration (the size of the read-out at that concentration, not a potency): 99.6%
Compound 4: middle estimate off by 3.6 percentage points, on the low side; measured number inside the range.
By their numbers in this assay, from the lowest: compound 2; then compound 1; then compounds 4 and 3 (each within the scatter of the next).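

In this assay, among the compounds shown here, the exchange of fluoro for methoxy on an aromatic carbon, para to a large group, gives a number 2.4 percentage points lower from compound 3 to compound 4 (within the scatter) and is the first single-place comparison available in this set, showing that this particular change does not separate the two compounds at the concentration tested. At this place on the six-membered aromatic ring of carbon only, the entering methoxy brings 2 heavy atoms and 1 hydrogen-bond acceptor where the leaving fluoro had 1 heavy atom and 0 hydrogen-bond acceptors, yet compound 4 reads 99.6% and stays with compound 3 at the weak-effect end of the scale. There is no independent measurement that accounts for this result.

The compounds shown leave open whether the reading would hold with an amine, a carboxylic acid or a longer alkoxy chain at this same place, since fluoro and methoxy are the only two groups seen there. They also leave open whether this exchange would behave in the same way on the cores of compound 1 and compound 2, or whether a change elsewhere on the shared core of compound 3 and compound 4 would move the reading beyond the scatter.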